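Compound 2 gains a methoxy: working notes

The source may report more compounds than this note shows. Statements on the series, on what has been measured and on what is new or still open speak of the compounds shown alone.

Compound 1 `COc1ccc(/C=C/C(=O)c2ccccc2-c2ccc(OC)c(OC)c2)cc1OC` gives 4900 nM
Compound 2 `COc1ccc(/C=C/C(=O)c2ccccc2-c2ccc(F)nc2)cc1` gives 2700 nM

Within the data shown here, in a functional assay on MCF7 cells (Homo sapiens) for antiproliferative activity, read by sulforhodamine B assay, with a stated time of 48 h (a higher number here means a weaker inhibitor, a lower number a stronger inhibitor), these are the only two measured compounds. The values of compound 2 and compound 1 lie within the scatter of each other, so the numbers do not separate them. Among the measured compounds shown here, no measured pair differs in one place only, so no single change has yet been measured directly.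

The next compound, compound 3 `COc1ccc(/C=C/C(=O)c2ccccc2-c2ccc(F)nc2)cc1OC`, is not yet measured. It differs from compound 2 by one change: methoxy in place of hydrogen on an aromatic carbon, on a six-membered aromatic ring of carbon only, ortho to a methoxy group and meta to a large group (methoxy in place of hydrogen on an aromatic carbon).

Compound 1 also carries this methoxy and gives 4900 nM in the same read-out, while compound 2 gives 2700 nM without it. On that basis, the expected 1.1-fold lower number from compound 2 to compound 3 (0.03 log units; within the scatter) stays within the scatter, with no direction favoured in this assay as far as can be judged. For compound 3 the estimated value is 2500 nM with an expected range of 900 nM to 7000 nM in this read-out.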

Compound 3, half-maximal inhibitory concentration: 2800 nM
Compound 3: the middle estimate sits 1.1-fold (0.05 log units) below what was measured; the measured number falls inside the stated range.
By their numbers in this assay, from the lowest: compounds 2, 3 and 1 (each within the scatter of the next).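

Methoxy at this position: what the step adds

In this assay, the methoxy in place of hydrogen on an aromatic carbon, ortho to a methoxy group and meta to a large group, now has a direct reading (a 1.0-fold higher number from compound 2 to compound 3 (0.02 log units; within the scatter)), so with the 6-fluoropyridin-3-yl group present, the numbers show no separable effect of this change. Among these compounds, the same compound also gives the first direct reading of 6-fluoropyridin-3-yl in place of 3,4-dimethoxyphenyl on an aromatic carbon (a 1.8-fold lower number from compound 1 to compound 3 (0.24 log units; within the scatter)), and this step also stays within the scatter, so neither single change separates the three compounds in this read-out. No supporting data bear on this result, and it remains a plain reading of the numbers.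

The compounds shown carry only hydrogen or methoxy at this position, which leaves open how an amine, a carboxylic acid or a longer chain such as ethoxy would read there. How the same methoxy reads with the 3,4-dimethoxyphenyl group in place also stays open, as does any reading of these compounds outside this single cell line.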